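Replacing the acetyl on the amine nitrogen: compound 3

This account rests on a few compounds, and the source may have more. Where it says the series, first, only, none or still open, it means among the compounds named here.

Measured so far:
- compound 1 `CC1(C)CC(NC(=S)Nc2cccc(C#N)c2)c2cc(Cl)ccc2O1`: 10000 nM
- compound 2 `CC(=O)NC1CC(C)(C)Oc2ccc(Cl)cc21`: "not determined" (no result reported)

In a functional assay on T98G cells (Homo sapiens) for inhibition, read by MTT assay, with a stated time of 72 h (on this read-out higher numbers stand for weaker inhibition and lower numbers for stronger inhibition), compound 1 gives 10000 nM. For compound 2, the acetyl analogue on the shared core, no number is available in this assay; the entry reads "not determined" (no result reported), so compound 2 stands nowhere on the scale yet and offers no anchor of its own.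

The step to compound 3 `CC(C)NC(=S)NC1CC(C)(C)Oc2ccc(Cl)cc21` is a group of 6 heavy atoms (4 carbon, 1 nitrogen, 1 sulfur; no ring) in place of a group of 3 heavy atoms (2 carbon, 1 oxygen; no ring), on an amine nitrogen. Among the compounds with values here, with no step between measured compounds recorded, the size and direction of the change in this assay cannot be read from a comparable pair. Within the data shown here, the only reference is compound 1, which also carries a thiocarbonyl-linked amine on the same core and sits at 10000 nM. On that basis compound 3 is expected to fall in the same weak region, without a claim on direction beyond the scatter.

Compound 3 is therefore expected to give 15000 nM in this assay, estimated between 5000 nM and 50000 nM, with a fair chance that only a limit is reported.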

Compound 3, half-maximal inhibitory concentration: 91000 nM
The estimate for compound 3 lay 6.1-fold (0.78 log units) below the measured number, and the stated range ends below it.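

In this assay, isopropyl in place of 3-cyanophenyl on the amide-type nitrogen gives a 9.1-fold higher number from compound 1 to compound 3 (0.96 log units; beyond the scatter), so with the thiocarbonyl link and the shared core held constant, the group at this position changes the read-out beyond the scatter. Of the two groups compared here, 3-cyanophenyl is the one that goes with the stronger inhibition, although this rests on a single pair and sets no trend for aryl against alkyl groups. The change from the acetyl of compound 2 to the larger thiocarbonyl-linked group of compound 3 cannot be read, as compound 2 has no number, so the contribution of the thiocarbonyl link itself remains unresolved. Nothing available accounts for the size or direction of the step.

Still open, going by these compounds, is whether an unsubstituted phenyl, a benzyl or a longer alkyl chain such as n-butyl on this nitrogen would fall between the isopropyl and 3-cyanophenyl compounds, which would separate the effect of the ring from that of the nitrile. Also open, on these data alone, is how a urea carbonyl in place of the thiocarbonyl would read on the same core.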